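A Morpholine Amide in Place of the Primary Amide

The compounds below may be only part of what the source reports. "The series", "measured", "known", "first", "only" and "open" are said of these compounds alone.

Compound 1 `CCOc1cc(NC(=O)C2(NC(=O)c3ccc4c(C5CCCC5)c(-c5ncc(Cl)cn5)n(C)c4c3)CCC2)ccc1/C=C/C(=O)OCc1ccccc1`, compound 2 `CCOc1cc(NC(=O)C2(NC(=O)c3ccc4c(C5CCCC5)c(-c5ncc(Cl)cn5)n(C)c4c3)CCC2)ccc1/C=C/C(=O)OCC(=O)OC` and compound 3 `CCOc1cc(NC(=O)C2(NC(=O)c3ccc4c(C5CCCC5)c(-c5ncc(Cl)cn5)n(C)c4c3)CCC2)ccc1/C=C/C(=O)OCC(N)=O` share one core and differ only at the ester end. In an ADME assay (liver) for pharmacokinetics, with Liver microsome (Homo sapiens) as the target, using microsomes (on this read-out higher numbers stand for a longer-lived compound and lower numbers for a shorter-lived compound), compound 1 gives > 5 h, which is a limit of the assay rather than a number (the limit of > 5 h in this assay, at which 1 of the 3 values shown sits). In this assay compound 2 gives 2.1 h, and compound 3 gives 0.983 h, the lower of the two numbers. The measured steps were an at least 2.3-fold lower number from compound 1 to compound 2 (0.37 log units; beyond the scatter), an at least 5.0-fold lower number from compound 1 to compound 3 (0.70 log units; beyond the scatter) and a 2.1-fold lower number from compound 2 to compound 3 (0.33 log units; beyond the scatter). Compound 4 `CCOc1cc(NC(=O)C2(NC(=O)c3ccc4c(C5CCCC5)c(-c5ncc(Cl)cn5)n(C)c4c3)CCC2)ccc1/C=C/C(=O)OCC(=O)N1CCOCC1` carries morpholin-4-yl in place of amino on a carbonyl carbon. Within the data shown here, only the step of a 2.1-fold lower number from compound 2 to compound 3 (0.33 log units; beyond the scatter) touches the same carbonyl carbon, and it was modest, so a small step is expected here, a 1.3-fold higher number from compound 3 to compound 4 (0.12 log units; within the scatter). Compound 4 is estimated at 1.3 h, between 0.5 h and 3 h.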

Compound 4, half-life: 0.667 h
Estimate against measurement, compound 4: 1.9-fold (0.29 log units) above; measured number inside the range.
By their numbers in this assay, from the lowest: compounds 4 and 3 (each within the scatter of the next); then compound 2. At a limit, above all of these: compound 1.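

Morpholin-4-yl in place of amino on the carbonyl carbon gives a 1.5-fold lower number from compound 3 to compound 4 (0.17 log units; within the scatter), so in this assay the larger ring and the primary amide cannot be told apart. In place of methoxy on that carbon, it gives a 3.1-fold lower number from compound 2 to compound 4 (0.50 log units; beyond the scatter), and the whole (morpholin-4-yl)carbonyl group in place of phenyl gives an at least 7.4-fold lower number from compound 1 to compound 4 (0.87 log units; beyond the scatter). Compound 1 stands at a limit, not at a number: the limit of > 5 h in this assay, at which 1 of the 4 values shown sits.

As far as these compounds go, what remains open is whether a carboxylic acid or a piperidine amide on this carbonyl carbon would fall with the two amides or with the methoxy ester.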